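A Halogen Swap at the Edge of Compound 1

The source may report more compounds than this note shows. Statements on the series, on what has been measured and on what is new or still open speak of the compounds shown alone.

Compound 1, `COc1ccc2cc([C@H](C)c3nnc(SCc4ccc(F)cc4)n3-c3ccc(F)cc3)ccc2c1`, was tested in a functional assay on PC-3 cells (Homo sapiens) for cytotoxicity, read by MTT assay; a lower number here means a stronger inhibitor, a higher number a weaker inhibitor. In this assay compound 1 returned <= 400000 nM, which is a limit of the assay rather than a number, so compound 1 stands only at that limit and not at a fixed point. Two neighbours differ from compound 1 in the group on the saturated chain carbon bound to a sulfur. Compound 2, `COc1ccc(CSc2nnc([C@@H](C)c3ccc4cc(OC)ccc4c3)n2-c2ccc(F)cc2)cc1`, gives 400000 nM in this assay, while compound 3, `COc1ccc2cc([C@H](C)c3nnc(SCc4c(Cl)cccc4Cl)n3-c3ccc(F)cc3)ccc2c1`, gives 216000 nM. Between those two the change is a 1.9-fold lower number from compound 2 to compound 3 (0.27 log units; within the scatter). The steps of a number no lower from compound 1 to compound 2 (the limit leaves the size open) and a step that the limit leaves unreadable from compound 1 to compound 3 cannot be sized because the limit of <= 400000 nM in this assay, at which 1 of the 3 values shown sits, covers compound 1.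

Compound 4, `COc1ccc2cc([C@H](C)c3nnc(SCc4ccc(F)cc4)n3-c3ccc(Cl)cc3)ccc2c1`, differs from compound 1 by chloro in place of fluoro on an aromatic carbon. Going by the values given here, no measured step touches that place; all three alter the group on the saturated chain carbon bound to a sulfur, and the single readable one, a 1.9-fold lower number from compound 2 to compound 3 (0.27 log units; within the scatter), lies within the scatter. The expectation is therefore a step no larger than the scatter, a step that the limit leaves unreadable from compound 1 to compound 4. Compound 4 is estimated at 250000 nM, within a range from 80000 nM to 600000 nM.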

Compound 4, half-maximal inhibitory concentration: 10800 nM
Compound 4: middle estimate off by 23-fold (1.36 log units), on the high side; the measured number lies below the stated range.
By their numbers in this assay, from the lowest: compound 4; then compounds 3 and 2 (each within the scatter of the next).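

No size can be given for the step from compound 1 to compound 4, because compound 1 rests on a limit rather than a number: the limit of <= 400000 nM in this assay, at which 1 of the 4 values shown sits.

The compounds shown leave open how far the change from 4-fluorophenyl to 4-chlorophenyl alone moves the number in this assay.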